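A chloro group added to a weakly active series

The source may hold more compounds than are shown below. What is called first, only, known or untested is meant among the compounds shown, and "the series" means these compounds.

Compound 1 `Fc1cccc(-c2nc(Nc3ccccc3)c3cc(F)ccc3n2)c1` is the reference point. For the measured compounds named here, in a functional assay on U-937 cells (Homo sapiens) for cytotoxicity, read by MTT assay, with a stated time of 48 h (a lower number here means a stronger inhibitor, a higher number a weaker inhibitor), compound 1 gives 45500 nM, the only plain number among the three measured compounds. Compound 2 `COc1ccccc1Nc1nc(-c2cccc(F)c2)nc2ccc(F)cc12` reaches only the limit of > 50000 nM in this assay. Compound 3 `Fc1ccc(Nc2nc(-c3cccc(F)c3)nc3ccc(F)cc23)cc1` likewise stops at the limit of > 50000 nM. The step from compound 1 to compound 4 `Fc1cccc(-c2nc(Nc3ccc(Cl)cc3)c3cc(F)ccc3n2)c1` is chloro in place of hydrogen on an aromatic carbon. Going by the values given here, two measured steps bear on this change: an at least 1.0-fold higher number from compound 1 to compound 2 (0.04 log units; that floor lies within the scatter) and an at least 1.0-fold higher number from compound 1 to compound 3 (0.04 log units; that floor lies within the scatter) both end at a limit (the limit of > 50000 nM in this assay, at which 2 of the 3 values shown sit), with floors inside the scatter. Compound 4 is therefore expected to give a number of about 65000 nM, between 30000 nM and 150000 nM, quite possibly reported again only as a limit. That expectation amounts to a 1.4-fold higher number from compound 1 to compound 4 (0.15 log units; within the scatter).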

Compound 4, half-maximal inhibitory concentration: 32700 nM
Compound 4: middle estimate off by 2.0-fold (0.30 log units), on the high side; measured number inside the range.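

For the compounds shown here, compound 4 gives a second plain number, so a group on this carbon can be compared directly with hydrogen for the first time: chloro gives a 1.4-fold lower number from compound 1 to compound 4 (0.14 log units; within the scatter). Chloro in place of fluoro gives an at least 1.5-fold lower number from compound 3 to compound 4 (0.18 log units; that floor lies within the scatter), and 4-chlorophenyl in place of 2-methoxyphenyl gives an at least 1.5-fold lower number from compound 2 to compound 4 (0.18 log units; that floor lies within the scatter). Compound 2 and compound 3 each stop at a limit rather than a number: the limit of > 50000 nM in this assay, at which 2 of the 4 values shown sit.

From the compounds shown here alone, it remains open whether any group at this position can move the number beyond the scatter. The effect of an amine or a carboxylic acid here is also unknown.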